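This account rests on a few compounds, and the source may have more. Where it says the series, first, only, none or still open, it means among the compounds named here.

Three compounds built around a trimethoxyphenyl-bearing triazole were tested in a functional assay on Jurkat cells (Homo sapiens) for antiproliferative activity, read by MTT assay, with a stated time of 72 h; on this read-out higher numbers stand for weaker inhibition and lower numbers for stronger inhibition. Compound 1 `COc1cc(-n2ncnc2-c2ccc(Cl)cc2)cc(OC)c1OC` returns only a limit in this assay, > 10000 nM. Compound 2 `COc1cc(-n2ncnc2-c2ccc(Cl)c(Cl)c2)cc(OC)c1OC` likewise returns only a limit, > 10000 nM. Compound 3 `COc1cc(-c2ncnn2-c2ccc(Cl)cc2)cc(OC)c1OC` also gives only a limit, > 10000 nM. The difference between the cores of compound 2 and compound 3 is not broken down here. Between compound 2 and compound 1 the change is hydrogen in place of chloro on an aromatic carbon, and the step that the two limits leave unreadable from compound 2 to compound 1 cannot be read because of the limit of > 10000 nM in this assay, at which 3 of the 3 values shown sit.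

Compound 4 `COc1cc(-c2ncnn2-c2ccccc2)cc(OC)c1OC` is not yet measured. It differs from compound 3 by hydrogen in place of chloro on an aromatic carbon, the same kind of change as that from compound 2 to compound 1, though there the place is ortho to a chloro group and meta to a large group, whereas here it is para to a large group. Since the earlier step is unreadable, nothing shows that removing chloro moves this read-out. Compound 4 is therefore expected to sit at the limit again, with an estimated step that the limit leaves unreadable from compound 3 to compound 4. The estimate for compound 4 in this assay is 15000 nM, spanning 5000 nM to 50000 nM.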

Compound 4, half-maximal inhibitory concentration: > 10000 nM
Compound 4 ended at the assay's limit; the forecaster's own chance of this, stated with the estimate: 80%; the middle value lies beyond the limit too.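

No step can be read from compound 3 to compound 4, because both return only a limit in this assay: the limit of > 10000 nM in this assay, at which 4 of the 4 values shown sit.

The compounds shown leave open whether any compound of this series gives a value inside the measurable range of this assay, and so which change, if any, moves this read-out.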